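Replacing a Fluorophenyl Group: Expected Microsomal Stability

The source may report more compounds than this note shows. Statements on the series, on what has been measured and on what is new or still open speak of the compounds shown alone.

Compound 1, `CCCCc1nc(=O)c(S(=O)(=O)c2ccc(-c3ccnc(NC(=O)C4CC4)c3)cc2)c(O)n1-c1c(OC)cccc1OC`: 72%
Compound 2, `CCCCc1nc(=O)c(S(=O)(=O)c2ccc(-c3cccnc3)cc2)c(O)n1-c1c(OC)cccc1OC`: 3%
Compound 3, `CCCCc1[nH]c(=O)c(S(=O)(=O)c2ccc(-c3ccc(F)cc3)cc2)c(O)c1-c1c(OC)cccc1OC`: "not determined" (no result reported)

In an ADME assay on microsomes from liver (Rattus norvegicus) for metabolic stability, using NADPH, with a stated time of 10 min (a lower number here means that less of the compound is left, a higher number that more of the compound is left), compound 1 gives 72%, while compound 2 gives 3%. Going by the values given here, the single measured step, a number 69 percentage points lower from compound 1 to compound 2 (beyond the scatter), shows that exchanging the group at this position can move the read-out strongly. Compound 3 has no number in this assay, so there is no starting point for the step. Compound 4, `CCCCc1[nH]c(=O)c(S(=O)(=O)c2ccc(-n3cc(Cl)ccc3=O)cc2)c(O)c1-c1c(OC)cccc1OC`, differs from compound 3 by a group of 8 heavy atoms (5 carbon, 1 nitrogen, 1 oxygen, 1 chlorine; one six-membered aromatic ring with 1 hetero atom) in place of a group of 7 heavy atoms (6 carbon, 1 fluorine; one six-membered aromatic ring of carbon only), on an aromatic carbon. Compound 3 and compound 4 share a core unlike that of compound 1 and compound 2, so the measured step carries over only loosely. A wide range is therefore expected, and compound 4 is estimated at 30%, between 3% and 80%.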

Compound 4, percent of the compound remaining: 72%
Estimate against measurement, compound 4: 42 percentage points below, and the stated range covers the measured number.
By their numbers in this assay, from the lowest: compound 2; then compounds 1 and 4 (each within the scatter of the next).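

Going by these compounds alone, with compound 3 standing without a number in this assay, no step from it to compound 4 can be read. Nothing shown gives a reason for the result of compound 4. The compounds shown leave open how the 4-fluorophenyl group and the group that replaces it in compound 4 compare in this read-out.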